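Halogen swap on the anilide of the pyridine N-oxide series

A few compounds are considered here, and "the series" means these few. Any claim that something is new, unique, unknown or untested is made for them only; others in the source may bear on it.

Compound 3 `Cc1cc(F)ccc1NC(=O)CN1CCC(c2cccc[n+]2[O-])CC1` gives 60 nM in a functional assay on HEK293 cells for agonist activity at D(4) dopamine receptor (Homo sapiens), read by FLIPR (a higher number here means that more compound is needed for the effect, a lower number that less compound is needed), and stands second highest of the three numbers: nearest is compound 1 `Cc1cc(C)cc(NC(=O)CN2CCC(c3cccc[n+]3[O-])CC2)c1` with 52 nM, furthest is compound 2 `O=C(CN1CCC(c2cccc[n+]2[O-])CC1)Nc1cccc(Cl)c1Cl` with 180 nM. The change to compound 4 `Cc1ccc(Cl)cc1NC(=O)CN1CCC(c2cccc[n+]2[O-])CC1` is 5-chloro-2-methylphenyl in place of 4-fluoro-2-methylphenyl on an amide-type nitrogen. Of the measured steps, a 1.2-fold higher number from compound 1 to compound 3 (0.06 log units; within the scatter) and a 3.0-fold lower number from compound 2 to compound 3 (0.48 log units; beyond the scatter) bear most on this swap of the anilide; a 3.5-fold higher number from compound 1 to compound 2 (0.54 log units; beyond the scatter) shows that a dichlorophenyl raised the number modestly. Only one chlorine enters here, so a small shift at most is expected, with compound 4 tending toward a slightly higher number than compound 3, as the expected step of a 1.3-fold higher number from compound 3 to compound 4 (0.12 log units; within the scatter) reflects. For compound 4 the estimate in this assay is 80 nM, within 30 nM to 220 nM.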

Compound 4, half-maximal effective concentration: 126 nM
Compound 4: middle estimate off by 1.6-fold (0.20 log units), on the low side, within the range that was stated.
By their numbers in this assay, from the lowest: compounds 1 and 3 (each within the scatter of the next); then compounds 4 and 2 (each within the scatter of the next).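

In this assay the step of a 2.1-fold higher number from compound 3 to compound 4 (0.32 log units; beyond the scatter) shows that this position on the amide-type nitrogen responds to a swap of one halogen, not only to two chlorines. The step of a 2.4-fold higher number from compound 1 to compound 4 (0.38 log units; beyond the scatter) also places the new group apart from 3,5-dimethylphenyl, whereas a 1.4-fold lower number from compound 2 to compound 4 (0.15 log units; within the scatter) does not separate it from 2,3-dichlorophenyl. No measured evidence accounts for the shift.

Compound 3 and compound 4 differ in both the halogen and its place on the ring, so these two changes remain unseparated. On these data alone, how a ring bearing an amine or a carboxylic acid would behave also remains open.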